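Replacing the Oxolanyl Group of Compound 1 with Fluorophenyl

This account rests on a few compounds, and the source may have more. Where it says the series, first, only, none or still open, it means among the compounds named here.

Measured compounds in a functional assay on CHO-K1 cells for antagonist activity at adenosine receptor A1 (Homo sapiens), read by a beta-galactosidase reporter and cAMP accumulation, with stated times of 15 min and 6 h; on this read-out lower numbers stand for stronger inhibition and higher numbers for weaker inhibition:
Compound 1 `Nc1nc(C2CCCO2)nc2sc(Cc3ccccc3)cc12` gives 2950 nM.
Compound 2 `Cc1csc(-c2nc(N)c3cc(Cc4ccccc4Cl)sc3n2)n1` gives 49.6 nM.
Compound 3 `N#Cc1cccc(-c2nc(N)c3cc(Cc4ccccc4Cl)sc3n2)c1` gives 24.8 nM.

Compound 1 stands highest of the three numbers in this assay; compound 2 sits far below it and compound 3 further still, both gaps lying beyond the scatter. Compound 4 `Nc1nc(-c2cccc(F)c2)nc2sc(Cc3ccccc3)cc12` arises from compound 1 by a single change: 3-fluorophenyl in place of oxolan-2-yl on an aromatic carbon.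

Within the data shown here, no measured step covers this change directly. Compound 2 and compound 3 carry a directly attached ring at the same position, but each also carries a chlorine on the benzyl group, so their distance from compound 1 cannot be split into the two contributions. Among the measured compounds shown here, the one single-place step, a 2.0-fold lower number from compound 2 to compound 3 (0.30 log units; within the scatter), shows that exchanging one such ring for another at this position leaves the number within the scatter. Compound 4 lacks the chlorine that compound 2 and compound 3 share, so its number is estimated to fall well below compound 1 but not as low as those two. Compound 4 is therefore expected to give 200 nM in this assay, with a range from 50 nM to 800 nM. The estimated step is a 15-fold lower number from compound 1 to compound 4 (1.17 log units; beyond the scatter).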

Compound 4, inhibition constant: 123 nM
The estimate for compound 4 lay 1.6-fold (0.21 log units) above the measured number; low and high end bracket the measured number.
By their numbers in this assay, from the lowest: compounds 3 and 2 (each within the scatter of the next); then compound 4; then compound 1.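

In this assay, the exchange of oxolan-2-yl for 3-fluorophenyl gives a 24-fold lower number from compound 1 to compound 4 (1.38 log units; beyond the scatter), a large step with the benzyl group left unchanged. Among these compounds, this is the first reading of the position between two ring nitrogen atoms that is free of any chlorine on the benzyl group, and it shows that the number responds strongly to replacing a five-membered non-aromatic ring with a six-membered aromatic ring of carbon only. The change alters the ring size, the aromatic character, the ring oxygen and the fluorine all at once, and no evidence is available that bears on which of these accounts for the step.

Going by these compounds, whether a phenyl group without the fluorine, a fluorine on another carbon of that ring, or a simple amine such as dimethylamino would give a similar number at this position remains open. Also open, on these data alone, is what a chlorine on the benzyl group would do to the number of compound 4.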